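Working notes: from cyclohexyl ether to catechol ether

This account rests on a few compounds, and the source may have more. Where it says the series, first, only, none or still open, it means among the compounds named here.

Measured in a functional assay on HeLa cells (Homo sapiens) for inhibition, read by CCK-8 assay, with a stated time of 48 h; on this read-out lower numbers stand for stronger inhibition and higher numbers for weaker inhibition (values as follows):
- compound 1 `COc1ccc(Oc2ccc([N+](=O)[O-])cc2-c2ccsc2S(=O)(=O)N2CCN(C(=S)Nc3ccc(Cl)cc3)CC2)cc1OC` gives > 50000 nM as a limit
- compound 2 `O=C(NCCNS(=O)(=O)c1ccc(-c2ccccc2O[C@H]2CC[C@@H](O)CC2)s1)Nc1cc(C(F)(F)F)cc(C(F)(F)F)c1` gives 14100 nM as a number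

Within the data shown here, compound 2 is the only compound with a number (14100 nM). Compound 1 stands at a limit (the limit of > 50000 nM in this assay, at which 1 of the 2 values shown sits). Compound 3 (`O=C(NCCNS(=O)(=O)c1ccc(-c2ccccc2Oc2ccc(O)c(O)c2)s1)Nc1cc(C(F)(F)F)cc(C(F)(F)F)c1`) changes compound 2 by 3,4-dihydroxyphenyl in place of 4-hydroxycyclohexyl on an oxygen on an aromatic ring on the same core, with 3,4-dihydroxyphenyl in place of 4-hydroxycyclohexyl on an oxygen on an aromatic ring. No measured step sizes this change in this assay, so only a modest move toward stronger inhibition is expected, and it may stay within the scatter. The expected step is small (a 1.6-fold lower number from compound 2 to compound 3 (0.19 log units; within the scatter)). Compound 3 is estimated at 9000 nM (expected range 2500 nM to 30000 nM).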

Compound 3, half-maximal inhibitory concentration: > 20000 nM
Compound 3: no number, only a limit; the forecaster's own chance of this, stated with the estimate: 10%; middle value at least 2.2-fold (0.34 log units) from the limit.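

In this assay, among these compounds, the only measured step at this position, on an oxygen on an aromatic ring, gives an at least 1.4-fold higher number from compound 2 to compound 3 (0.15 log units; that floor lies within the scatter). Compound 3 is read only as a limit and not as a number: the limit of > 20000 nM in this assay, at which 1 of the 3 values shown sits. Replacing 4-hydroxycyclohexyl with 3,4-dihydroxyphenyl therefore shows no gain in inhibition, but the floor of the step lies within the scatter and the full size of the change stays unread.

Still open, as far as these compounds go, is whether the ring type or the hydroxyl groups govern this position. Unsubstituted cyclohexyl, unsubstituted phenyl or 4-aminocyclohexyl on the same oxygen would help separate these.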